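The compounds below may be only part of what the source reports. "The series", "measured", "known", "first", "only" and "open" are said of these compounds alone.

Measured so far:
compound 1 `Nc1scc(CN2CCN(c3ccc(Cl)c(C(F)(F)F)c3)CC2)c1C(=O)c1ccc(Cl)cc1` — 3%
compound 2 `Nc1scc(CN2CCC(c3ccc(Cl)cc3)CC2)c1C(=O)c1ccc(Cl)cc1` — 6%

In an assay on CHO cells for displacement of a labelled ligand from adenosine receptor A3 (Homo sapiens), read by scintillation counting, with a stated time of 120 min, tested at 10 uM (on this read-out higher numbers stand for more inhibition at the one concentration tested (going by the name of the read-out) and lower numbers for less inhibition), compound 1 gives 3%. Compound 2 gives 6% in this assay. The gap between the two numbers lies within the usual scatter, so compound 1 cannot be told apart from compound 2 on these data; both sit at the low end of what this assay can report. For the measured compounds named here, no pair of measured compounds differing in a single place is available, so no measured step exists to lean on.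

Compound 3 `Nc1scc(CN2CCN(c3cccc(F)c3F)CC2)c1C(=O)c1ccc(Cl)cc1` is the next compound and differs from compound 1 in one place: 2,3-difluorophenyl in place of 4-chloro-3-(trifluoromethyl)phenyl on an amine nitrogen in a ring. With both measured compounds near zero, the expected step is a number 2 percentage points higher from compound 1 to compound 3 (within the scatter), that is, no change beyond the scatter. For compound 3 the value expected in this assay is 5%, with a range from 0% to 20%.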

Compound 3, a percentage reported as inhibition, at one concentration (the size of the read-out at that concentration, not a potency): 0%
Compound 3: middle estimate off by 5 percentage points, on the high side, within the range that was stated.
By their numbers in this assay, from the lowest: compounds 3, 1 and 2 (each within the scatter of the next).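

In this assay, for the compounds shown here, 2,3-difluorophenyl in place of 4-chloro-3-(trifluoromethyl)phenyl on the amine nitrogen in the ring gives a number 3 percentage points lower from compound 1 to compound 3 (within the scatter), the first single-place comparison. The smaller aryl group with no chlorine or trifluoromethyl therefore does not lift the read-out, but with both values at the low end of the scale, the step cannot show whether this position matters for displacement of the labelled ligand. No measured evidence on either aryl group is available to interpret the result.

The compounds shown leave open whether any group on this nitrogen can raise the read-out, for example a carboxylic acid on the phenyl ring, or a longer alkyl chain or a benzyl group in place of the aryl group. They also leave open whether changes elsewhere on the shared core would give a readable signal.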